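Swapping a Piperazine for a Benzylamine on an Inactive Core

This account rests on a few compounds, and the source may have more. Where it says the series, first, only, none or still open, it means among the compounds named here.

Compound 1, `Brc1ccc(Nc2nc(/C=C/c3ccccc3)nc3ccsc23)cc1`: in a functional assay on L02 cells (Homo sapiens) for inhibition, read by Griess assay, with stated times of 1 h and 24 h (a lower number here means a stronger inhibitor, a higher number a weaker inhibitor), compound 1 gives > 1000000 nM, which is a limit of the assay and not a measured number.
Compound 2, `COc1cc(/C=C/c2nc(N3CCN(C)CC3)c3sccc3n2)cc(OC)c1OC`: in this assay compound 2 gives > 1000000 nM, likewise a limit of the assay.

Among the measured compounds shown here, compound 2 therefore stands at the edge of what this assay can report, and the limit of > 1000000 nM in this assay, at which 2 of the 2 values shown sit, shows that every value known so far sits at that same edge. For the measured compounds named here, no step between two measured compounds is available, so nothing yet shows how any change on this core moves the read-out. Compound 3, `COc1cc(/C=C/c2nc(NCc3ccc(C)cc3)c3sccc3n2)cc(OC)c1OC`, arises from compound 2 by one change: (4-methylbenzyl)amino in place of 4-methylpiperazin-1-yl on an aromatic carbon. With both known compounds at the limit, the step that the limit leaves unreadable from compound 2 to compound 3 is expected to be none beyond the usual scatter, and the result is more likely another limit than a number. Compound 3 is expected to give about 1500000 nM, in a range from 200000 nM to 10000000 nM.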

Compound 3, half-maximal inhibitory concentration: > 1000000 nM
Compound 3 gave a limit, no number; the forecaster's own chance of this, stated with the estimate: 75%; the middle value is on the limit's open side.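

In this assay compound 3 gives > 1000000 nM, which is a limit of the assay and not a number. Among the compounds shown here, compound 2 also sits at a limit, so no step between compound 2 and compound 3 can be read. The compounds shown leave open whether any change on the shared core can give a measured number, as all of them sit at the same edge: the limit of > 1000000 nM in this assay, at which 3 of the 3 values shown sit.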